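Dichlorophenyl to chlorophenyl in a purine series

This account rests on a few compounds, and the source may have more. Where it says the series, first, only, none or still open, it means among the compounds named here.

Measured so far:
compound 1, `CN1CCN(c2nc(-c3ccc(Cl)c(Cl)c3)nc3[nH]cnc23)CC1`: > 80%
compound 2, `Clc1ccc(Cl)c(-c2nc(N3CCCCC3)c3nc[nH]c3n2)c1`: > 80%
compound 3, `CN1CCN(c2nc(-c3ccc(Cl)cc3)nc3[nH]cnc23)CC1`: > 80%

In an assay on cells for displacement of a labelled ligand from adenosine receptor A3 (Homo sapiens), read by scintillation counting and radioligand binding, with a stated time of 180 min, tested at 10 uM (on this read-out higher numbers stand for more inhibition at the one concentration tested (going by the name of the read-out) and lower numbers for less inhibition), compound 1 reaches a limit of the assay, > 80%. Compound 3 also sits at a limit in this assay, > 80%. Compound 2 likewise returns only a limit in this assay, > 80%. The difference between compound 1 and compound 3 is hydrogen in place of chloro on an aromatic carbon, and the step that the two limits leave unreadable from compound 1 to compound 3 cannot be sized, since (the limit of > 80% in this assay, at which 3 of the 3 values shown sit).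

Compound 4, `Clc1cccc(-c2nc(N3CCCCC3)c3nc[nH]c3n2)c1`, is not yet measured in this assay. It relates to compound 2 by hydrogen in place of chloro on an aromatic carbon, the same kind of change as from compound 1 to compound 3, though the surroundings differ: in compound 1 the leaving chloro sits ortho to a chloro group and meta to a large group, whereas in compound 2 it sits ortho to a large group and para to a chloro group. The difference between the cores of compound 1 and compound 2 is not broken down here.

Given that compound 2 shows > 80% and that every value so far sits at the limit, compound 4 is expected to give 85% in this assay, between 65% and 97%, an expected step that the limit leaves unreadable from compound 2 to compound 4.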

Compound 4, a percentage reported as inhibition, at one concentration (the size of the read-out at that concentration, not a potency): > 80%
Compound 4: only a limit was reported (the forecaster's own chance of this, stated with the estimate: 70%); the middle value is on the limit's open side.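

No step can be read between compound 2 and compound 4, since both values are limits and not numbers: the limit of > 80% in this assay, at which 4 of the 4 values shown sit.

The compounds shown leave open how large the effect of hydrogen in place of chloro is in either pair, and whether it differs between compound 1 to compound 3 and compound 2 to compound 4.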